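Cycloheptyl exchanged for a fused bicyclic acyl group

A few compounds are considered here, and "the series" means these few. Any claim that something is new, unique, unknown or untested is made for them only; others in the source may bear on it.

Three compounds of the series have been run in an ADME assay on MT4 cells (Homo sapiens) for cytotoxicity, with a stated time of 5 days; a higher number here means that more compound is tolerated, a lower number that less compound is tolerated. Compound 1 `CC1=CC[C@H](C(=O)N(c2cc(C#CC(C)(C)C)sc2C(=O)O)[C@H]2CC[C@](O)(CO[C@H]3CCOC3)CC2)CC1` carries 4-methylcyclohex-3-en-1-yl on a carbonyl carbon. In this assay compound 1 gives only a limit, > 20000 nM. Compound 2 `CC(C)(C)C#Cc1cc(N(C(=O)[C@H]2CC[C@H](C)CC2)[C@H]2CC[C@](O)(CO[C@H]3CCOC3)CC2)c(C(=O)O)s1` differs by 4-methylcyclohexyl in place of 4-methylcyclohex-3-en-1-yl on a carbonyl carbon. In this assay compound 2 likewise gives only a limit, > 20000 nM. The step that the two limits leave unreadable from compound 1 to compound 2 therefore cannot be read. Compound 3 `CC(C)N(C(=O)C1CCCCCC1)c1cc(C#CC(C)(C)C)sc1C(=O)O` carries cycloheptyl on a carbonyl carbon. In this assay compound 3 also gives only a limit, > 20000 nM. All values shown sit at the limit of > 20000 nM in this assay, at which 3 of the 3 values shown sit, so no ordering among these compounds can be read.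

Compound 4 `CC(C)N(C(=O)[C@H]1[C@@H]2CCCC[C@@H]21)c1cc(C#CC(C)(C)C)sc1C(=O)O` is not yet measured. Its change from compound 3 is a group of 7 heavy atoms (7 carbon; one three-membered non-aromatic ring of carbon only, one six-membered non-aromatic ring of carbon only) in place of a group of 7 heavy atoms (7 carbon; one seven-membered non-aromatic ring of carbon only), on a carbonyl carbon. Going by the values given here, no measured step bears directly on this exchange; the one step that touches the carbonyl substituent, a step that the two limits leave unreadable from compound 1 to compound 2, is unreadable. Because the limit of > 20000 nM in this assay, at which 3 of the 3 values shown sit, holds for every compound measured, compound 4 is expected to stay at the limit as well. The expected step from compound 3 is a step that the limit leaves unreadable from compound 3 to compound 4, no change beyond the scatter. The estimate for compound 4 is 25000 nM, with a range from 12000 nM to 60000 nM.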

Compound 4, half-maximal cytotoxic concentration: > 20000 nM
Compound 4: no number, only a limit (the forecaster's own chance of this, stated with the estimate: 85%); the middle value is on the limit's open side.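

In this assay, going by these compounds alone, compound 4 gives > 20000 nM, which is a limit and not a number, so no step from compound 3 to compound 4 can be read, and the series offers only one shared reading: the limit of > 20000 nM in this assay, at which 4 of the 4 values shown sit. The compounds shown leave open how far any of them lies beyond that limit, and whether the carbonyl substituent changes tolerance at all.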